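Series notes: from compound 3 to compound 4, one change

This account rests on a few compounds, and the source may have more. Where it says the series, first, only, none or still open, it means among the compounds named here.

Compound 1 `C#CCOc1ccc2oc(=O)ccc2c1`: "not determined" (no result reported) in a functional assay on PC-3 cells (Homo sapiens) for cytotoxicity, read by MTT assay, with a stated time of 48 h; on this read-out lower numbers stand for stronger inhibition and higher numbers for weaker inhibition
Compound 2 `O=c1ccc2cc(OCc3cc(-c4cccc(Cl)c4)no3)ccc2o1`: "not determined" (no result reported) in this assay
Compound 3 `O=c1ccc2cc(OCc3cc(-c4ccccc4[N+](=O)[O-])no3)ccc2o1`: 8200 nM

Among the compounds with values here, compound 3 holds the only number in the set; compound 1 and compound 2 carry no result, so no step between measured compounds can be read. Compound 4 `COc1ccccc1-c1cc(COc2ccc3oc(=O)ccc3c2)on1` is not yet measured. It differs from compound 3 in one place: methoxy in place of nitro on an aromatic carbon. Within the data shown here, with no measured step to lean on, the size of the change is open; the working expectation is a step of no more than the usual scatter, with no direction claimed, since the only anchor is compound 3 at 8200 nM. On that basis, the step from compound 3 to compound 4 is expected to be a 1.0-fold lower number from compound 3 to compound 4 (0.01 log units; within the scatter). Compound 4 is therefore estimated at 8000 nM in this assay, with a range from 2500 nM to 25000 nM.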

Compound 4, half-maximal inhibitory concentration: 22400 nM
Compound 4: middle estimate off by 2.8-fold (0.45 log units), on the low side, and the stated range covers the measured number.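

In this assay, within the data shown here, the change from 2-nitrophenyl to 2-methoxyphenyl gives the first readable step: a 2.7-fold higher number from compound 3 to compound 4 (0.44 log units; beyond the scatter). This place on the aromatic ring therefore affects the read-out, and of these two groups, nitro goes with the lower number. Nothing at hand accounts for the step.

Steps to compound 1 and compound 2 cannot be read. Open, from the compounds shown here alone, is how an amine, a carboxylic acid or a longer chain such as butoxy would read at this place, and whether the trend holds beyond this single pair.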